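The source may report more compounds than this note shows. Statements on the series, on what has been measured and on what is new or still open speak of the compounds shown alone.

Three compounds sharing one core were examined in a functional assay on SK-OV-3 cells (Homo sapiens) for antiproliferative activity, read by MTT assay, with a stated time of 24 h; a higher number here means a weaker inhibitor, a lower number a stronger inhibitor. Compound 1 `COc1ccc(/C=C/C(=O)c2ccc(OC)c3c2OC(C)(C)C=C3)cn1` reaches only a limit there, > 10000 nM. Compound 2 `COc1ccc(C(=O)/C=C/c2ccco2)c2c1C=CC(C)(C)O2` likewise gives only a limit, > 10000 nM. Among the compounds with values here, compound 3 `COc1ccc(C(=O)/C=C/c2ccccn2)c2c1C=CC(C)(C)O2` gives 8390 nM, the only number among the three values shown. The steps of an at least 1.1-fold lower number from compound 1 to compound 3 (0.07 log units; that floor lies within the scatter) and an at least 1.1-fold lower number from compound 2 to compound 3 (0.07 log units; that floor lies within the scatter) both rest on (the limit of > 10000 nM in this assay, at which 2 of the 3 values shown sit), and a step that the two limits leave unreadable from compound 1 to compound 2 cannot be read at all. Compound 4 `COc1ccc(C(=O)/C=C/c2cc(Cl)ccc2O)c2c1C=CC(C)(C)O2` differs from compound 3 by 5-chloro-2-hydroxyphenyl in place of pyridin-2-yl on a double-bonded chain carbon bound to a double-bonded chain carbon. Within the data shown here, no measured step exchanges this particular group, and the readable steps have floors within the scatter, so no step beyond the scatter is expected in this assay. Compound 4 is therefore estimated at 5000 nM, between 1500 nM and 10000 nM, which means an expected step of a 1.7-fold lower number from compound 3 to compound 4 (0.22 log units; within the scatter).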

Compound 4, half-maximal inhibitory concentration: 6270 nM
Compound 4: middle estimate off by 1.3-fold (0.10 log units), on the low side; the range from low to high includes it.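

In this assay the exchange of pyridin-2-yl for 5-chloro-2-hydroxyphenyl, which brings in a hydrogen-bond donor, gives a 1.3-fold lower number from compound 3 to compound 4 (0.13 log units; within the scatter) and so leaves the read-out within the scatter at this position. The other two readings are an at least 1.5-fold lower number from compound 2 to compound 4 (0.20 log units; that floor lies within the scatter) and an at least 1.5-fold lower number from compound 1 to compound 4 (0.20 log units; that floor lies within the scatter) and neither shows more, since both rest on a limit: the limit of > 10000 nM in this assay, at which 2 of the 4 values shown sit.

The compounds shown leave open whether any group at this place gives a step beyond the scatter. They also leave open what a phenyl carrying only the chlorine or only the hydroxyl would give, or one carrying an amine or a carboxylic acid.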